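A few compounds are considered here, and "the series" means these few. Any claim that something is new, unique, unknown or untested is made for them only; others in the source may bear on it.

Three compounds have been measured in an assay on C6 cells for antagonist activity at prostaglandin E2 receptor EP2 subtype (Homo sapiens), read by TR-FRET, with stated times of 10 min and 40 min, tested at 1 uM; a lower number here means a stronger inhibitor, a higher number a weaker inhibitor:

compound 1 `COc1cc(/C=C/C(=O)NCCn2c(C)cc3ccccc32)cc(OC)c1OCCO`, giving 3.7 nM
compound 2 `COc1cc(/C=C/C(=O)NCCn2c(C(F)(F)F)cc3ccccc32)cc(OC)c1OCCO`, giving 58.3 nM
compound 3 `Cc1cc(/C=C/C(=O)NCCn2c(C(F)(F)F)cc3ccccc32)cc(C)c1F`, giving 306 nM

Compound 2 and compound 1 share one core and differ in a single group, (methyl in place of trifluoromethyl on an aromatic carbon). That change gave a 16-fold lower number from compound 2 to compound 1 (1.20 log units; beyond the scatter). Compound 3 carries a different core; the difference between the cores of compound 3 and compound 2 is not broken down here, and in this assay compound 3 stands highest of the three.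

Compound 4 `Cc1cc(/C=C/C(=O)NCCn2c(C)cc3ccccc32)cc(C)c1F` has not been measured. It relates to compound 3 exactly as compound 1 relates to compound 2, (methyl in place of trifluoromethyl on an aromatic carbon), and the place of the change is the same, so this is the same change. The expectation rests on a 16-fold lower number from compound 2 to compound 1 (1.20 log units; beyond the scatter), tempered by the different core. The expected step is a 12-fold lower number from compound 3 to compound 4 (1.09 log units; beyond the scatter). Compound 4 is estimated at 25 nM, most likely between 8 nM and 80 nM.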

Compound 4, antagonist equilibrium constant: 3.4 nM
Compound 4: middle estimate off by 7.4-fold (0.87 log units), on the high side, and the stated range ends above it.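

Replacing trifluoromethyl with methyl gave a 90-fold lower number from compound 3 to compound 4 (1.95 log units; beyond the scatter). The change lowered the number on both cores, so its direction carried over, but its size did not: the same change on two cores in this assay, a 16-fold lower number (1.20 log units; beyond the scatter) from compound 2 to compound 1 and a 90-fold lower number (1.95 log units; beyond the scatter) from compound 3 to compound 4, 5.7-fold (0.76 log units) apart, beyond the scatter of two such steps

Among the compounds shown here, with only two cores, this does not show why the size differs, or how large the step would be on a third core. The compounds shown leave open whether another group in the same place, such as ethyl, a chlorine atom or a nitrile, would do as well as methyl. They also leave open how this change would behave on a core carrying an amine or a carboxylic acid.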